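This account rests on a few compounds, and the source may have more. Where it says the series, first, only, none or still open, it means among the compounds named here.

Series notes, hydroxamate sulfonamides.

Compound 1, `CC[C@H](C)[C@H](NS(=O)(=O)c1cc(C)c(Cl)cc1C)C(=O)N[C@@H](CNC(=O)OCc1ccccc1)C(=O)NO`, is the anchor of the set. In an assay on isolated protein for inhibition of bone morphogenetic protein 1 (Homo sapiens) (a higher number here means a weaker inhibitor, a lower number a stronger inhibitor), compound 1 gives 67 nM. For the measured compounds named here, the only other measured member is compound 2, `CC[C@@H](C)[C@@H](NC(=O)OCc1ccccc1)C(=O)NCC(NCc1ccccc1)C(=O)NO`, which carries a carbamate and a benzylamine in place of the sulfonamide and the carbamate-bearing side chain of compound 1; in this assay compound 2 gives 94 nM. Of the two numbers that of compound 1 is the lower, but the two lie within the usual scatter of each other, so neither compound can be called the stronger inhibitor on this evidence. Going by the values given here, no pair of measured compounds differs in a single place, so no step has been sized.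

Compound 3, `CC[C@H](C)[C@H](NS(=O)(=O)c1ccc(Br)c(Br)c1)C(=O)N[C@@H](CNC(=O)OCc1ccccc1)C(=O)NO`, is the next single-point variation on compound 1. The change is 3,4-dibromophenyl in place of 4-chloro-2,5-dimethylphenyl on a sulfonyl sulfur. Among the compounds with values here, no measured pair shows what exchanging one aryl group for another on the sulfonyl sulfur does in this assay, so the expected step from compound 1 to compound 3, a 1.3-fold higher number from compound 1 to compound 3 (0.13 log units; within the scatter), is set close to zero, with a wide margin in either direction. Compound 3 is therefore estimated at 90 nM in this assay, within a range of 30 nM to 300 nM.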

Compound 3, half-maximal inhibitory concentration: 26 nM
Compound 3: the middle estimate sits 3.5-fold (0.54 log units) above what was measured, outside the stated range (below it).
By their numbers in this assay, from the lowest: compound 3; then compounds 1 and 2 (each within the scatter of the next).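

In this assay, for the compounds shown here, 3,4-dibromophenyl in place of 4-chloro-2,5-dimethylphenyl on a sulfonyl sulfur gives a 2.6-fold lower number from compound 1 to compound 3 (0.41 log units; beyond the scatter) and is the first single-place step. It shows that the number responds to the aryl group on the sulfonyl sulfur while the rest of compound 1 stays fixed, a response that the comparison of compound 1 with compound 2 could not isolate. The exchange alters the halogen and the methyl groups together, and no available evidence accounts for the step.

The compounds shown do not separate the contribution of the two bromine atoms from that of losing the chlorine and the two methyl groups, and they leave open whether a single bromine would retain the lower number of compound 3. They also leave open how an unsubstituted phenyl, a 3,4-dichlorophenyl or a pyridine ring on the same sulfonyl sulfur would compare, and whether the step carries over to the side chain of compound 2.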